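Methyl in place of dimethylamino on a sulfonyl sulfur

The source may report more compounds than this note shows. Statements on the series, on what has been measured and on what is new or still open speak of the compounds shown alone.

Measured in an ADME assay on a cell-free system (plasma, Homo sapiens); on this read-out higher numbers stand for a larger free fraction and lower numbers for a smaller free fraction:
- compound 1 `COCCN(C)S(=O)(=O)c1ccc(C)c(C#Cc2cc(Cl)ccc2OCC(=O)O)c1`: 0.006
- compound 2 `CS(=O)(=O)c1ccc(Cl)c(C#Cc2cc(Cl)ccc2OCC(=O)O)c1`: 0.007
- compound 3 `Cc1ccc(S(=O)(=O)N(C)C)cc1C#Cc1cc(Cl)ccc1OCC(=O)O`: 0.004

Compound 3 gives 0.004, and that value lies within the scatter of both other compounds, so the three form a single group in this assay. Compound 4 `Cc1ccc(S(C)(=O)=O)cc1C#Cc1cc(Cl)ccc1OCC(=O)O` departs from compound 3 by one change: methyl in place of dimethylamino on a sulfonyl sulfur. In words, this is methyl in place of dimethylamino on a sulfonyl sulfur, or dimethylsulfamoyl to methylsulfonyl.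

Within the data shown here, no measured step makes this exact swap. The nearest evidence is a 1.5-fold lower number from compound 1 to compound 3 (0.18 log units; within the scatter), which alters a group on the sulfonamide nitrogen, the same nitrogen that leaves with the dimethylamino here. That step stays within the scatter. Compound 2, which also carries methylsulfonyl, gives 0.007, again within the scatter of the value for compound 3. Nothing measured therefore points to a change beyond the scatter in this assay, although the data cannot exclude one. The expected step is a 1.5-fold higher number from compound 3 to compound 4 (0.18 log units; within the scatter), which would not stand out from repeat measurements. For compound 4 the estimated unbound fraction is 0.006, with an expected range from 0.003 to 0.012.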

Compound 4, unbound fraction: 0.017
Compound 4: the middle estimate sits 2.8-fold (0.45 log units) below what was measured, outside the stated range (above it).
By their numbers in this assay, from the lowest: compounds 3, 1 and 2 (each within the scatter of the next); then compound 4.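

Methyl on the sulfonyl sulfur proves to be a change that this assay can register: the swap from dimethylamino gives a 4.3-fold higher number from compound 3 to compound 4 (0.63 log units; beyond the scatter), whereas the earlier step on the sulfonamide nitrogen stayed within the scatter. The swap from (2-methoxyethyl)(methyl)amino to methyl on the same sulfur points the same way, with a 2.8-fold higher number from compound 1 to compound 4 (0.45 log units; beyond the scatter), so compound 4 stands apart from both sulfonamides and the two share a side despite their different nitrogen groups. Methylsulfonyl alone does not set the number, since methyl in place of chloro on an aromatic carbon gives a 2.4-fold higher number from compound 2 to compound 4 (0.39 log units; beyond the scatter), which makes compound 4 the only one of the four with steps to all the others beyond the scatter.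

Nothing in the data shown accounts for either effect. On these data alone, it remains open whether ethyl or plain amino on the sulfonyl sulfur would read like methyl or like dimethylamino, and whether the step from dimethylamino to methyl would hold with chloro or methoxy on the aromatic carbon that carries methyl in compound 3.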